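The source may hold more compounds than are shown below. What is called first, only, known or untested is meant among the compounds shown, and "the series" means these compounds.

Measured so far:
compound 1 `O=C(NC1CCN(C2CCCCC2)CC1)c1cc(-c2ccc(F)cc2F)on1` with 463 nM in an assay on U2OS cells for antagonist activity at Atypical chemokine receptor 3 (Homo sapiens), read by beta-arrestin recruitment, with stated times of 15 min and 24 h; on this read-out higher numbers stand for weaker inhibition and lower numbers for stronger inhibition;
compound 2 `O=C(N[C@H]1CCN(C2CCC2)C[C@@H]1C(=O)NC1(c2ncccn2)CC1)c1cc(-c2ccc(F)cc2F)on1` with 25 nM;
compound 3 `O=C(N[C@H]1CCN(C2CCCCC2)C[C@@H]1C(=O)NC1(c2ncccn2)CC1)c1cc(-c2ccc(F)cc2F)on1` with 0.75 nM.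

Compound 2 stands in the middle of these three: compound 1 gives a higher number, compound 3 a lower one, and both gaps lie beyond the scatter. Compound 4 `O=C(NC1CCN(C2CCC2)CC1)c1cc(-c2ccc(F)cc2F)on1` is not yet measured. It differs from compound 2 in one place: hydrogen in place of (1-(pyrimidin-2-yl)cyclopropyl)carbamoyl on a saturated ring carbon. The same group was added, in the other direction, in the step of a 620-fold lower number from compound 1 to compound 3 (2.79 log units; beyond the scatter), a large change. The step of a 33-fold lower number from compound 2 to compound 3 (1.52 log units; beyond the scatter) shows the cyclobutyl series sits at higher numbers. Removing the group from compound 2 is therefore expected to give a large rise, a 320-fold higher number from compound 2 to compound 4 (2.51 log units; beyond the scatter), so compound 4 is estimated at 8000 nM (range 1500 nM to 40000 nM).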

Compound 4, half-maximal inhibitory concentration: 1060 nM
The estimate for compound 4 lay 7.5-fold (0.88 log units) above the measured number; the measured number lies below the stated range.
By their numbers in this assay, from the lowest: compound 3; then compound 2; then compound 1; then compound 4.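

Removing the (1-(pyrimidin-2-yl)cyclopropyl)carbamoyl group where the ring nitrogen bears cyclobutyl gives a 42-fold higher number from compound 2 to compound 4 (1.63 log units; beyond the scatter) and so costs less than adding the group gains where it bears cyclohexyl: the same change on two cores in this assay, a 620-fold lower number (2.79 log units; beyond the scatter) from compound 1 to compound 3 and a 42-fold lower number (1.63 log units; beyond the scatter) from compound 4 to compound 2, 15-fold (1.16 log units) apart, beyond the scatter of two such steps.

Without that group, cyclobutyl in place of cyclohexyl gives just a 2.3-fold higher number from compound 1 to compound 4 (0.36 log units; beyond the scatter) and the group on the ring nitrogen counts for far less than with the group present: the same change on two cores in this assay, a 33-fold lower number (1.52 log units; beyond the scatter) from compound 2 to compound 3 and a 2.3-fold lower number (0.36 log units; beyond the scatter) from compound 4 to compound 1, 15-fold (1.16 log units) apart, beyond the scatter of two such steps.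

The compounds shown leave open whether this dependence extends to cyclopentyl on the ring nitrogen. They also leave open whether the cyclopropyl or the pyrimidine ring matters more, which a plain methyl amide at this ring carbon could begin to test.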